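Ring and Fluorine in Place of Isopropyl on an Amide

This account rests on a few compounds, and the source may have more. Where it says the series, first, only, none or still open, it means among the compounds named here.

Measured so far in an assay on SH-EP1 cells for agonist activity at Neuronal acetylcholine receptor; alpha4/beta2 (Homo sapiens), read by FLIPR and calcium flux; a higher number here means that more compound is needed for the effect, a lower number that less compound is needed:
compound 1, `CC(=O)N1CC2CC(C1)N2`, gives 9700 nM
compound 2, `CC(C)C(=O)N1CC2CC(C1)N2`, gives 20000 nM
compound 3, `O=C(C1CCCC1)N1CC2CC(C1)N2`, gives 29000 nM

All three share the same bicyclic diamine core, and differ only in the group on the carbonyl carbon of the amide. Compound 2 stands second highest of the three numbers: compound 3 sits above it, though their two values lie within the usual scatter, while compound 1 lies clearly below, as the step of a 2.1-fold higher number from compound 1 to compound 2 (0.31 log units; beyond the scatter) shows when isopropyl replaces methyl.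

The next compound, compound 4, `O=C([C@H]1C[C@@H]1F)N1CC2CC(C1)N2`, carries 2-fluorocyclopropyl in place of isopropyl on a carbonyl carbon. Within the data shown here, only one measured step bears on this change, the one from compound 1 to compound 2, and it was modest. Among the measured compounds shown here, a group with one more heavy atom than isopropyl, including a small ring and a fluorine, has no direct precedent in these three compounds; compound 3 with its larger ring gives the highest number, but that gap to compound 2 is within the scatter. The change is therefore expected to move the number little, if at all, in this assay: the step of a 1.3-fold lower number from compound 2 to compound 4 (0.12 log units; within the scatter) is expected to stay within the scatter. Compound 4 is estimated at 15000 nM, within a range of 5000 nM to 45000 nM.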

Compound 4, half-maximal effective concentration: 2800 nM
Estimate against measurement, compound 4: 5.4-fold (0.73 log units) above; measured number outside the range, below it.
By their numbers in this assay, from the lowest: compound 4; then compound 1; then compounds 2 and 3 (each within the scatter of the next).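

In this assay, among these compounds, 2-fluorocyclopropyl in place of isopropyl on the carbonyl carbon gives a 7.1-fold lower number from compound 2 to compound 4 (0.85 log units; beyond the scatter), a much larger step than the earlier compounds showed at this position. The same group in place of methyl gives a 3.5-fold lower number from compound 1 to compound 4 (0.54 log units; beyond the scatter), so a group with more heavy atoms than methyl need not raise the number here: compound 2 fits that earlier rise, while compound 4 goes against it. No measurement shown here explains this reversal.

The ring and the fluorine enter together, so the compounds shown leave open which of them goes with the lower number. A plain cyclopropyl on the same carbonyl carbon would separate the two, and a 2-fluorocyclopropyl with the opposite arrangement at its stereocentres would show whether that arrangement matters.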